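The source may report more compounds than this note shows. Statements on the series, on what has been measured and on what is new or still open speak of the compounds shown alone.

Measured so far in a functional assay on DU-145 cells (Homo sapiens) for antiproliferative activity, read by MTT assay, with a stated time of 72 h; a higher number here means a weaker inhibitor, a lower number a stronger inhibitor:
- compound 1, `CN(c1ccccc1)S(=O)(=O)C1CC2OC1C(c1ccc(NC(=O)CCCCCCC(=O)O)cc1)=C2c1ccc(O)cc1`: compound 1 gives > 100000 nM, which is a limit of the assay and not a number.
- compound 2, `Cc1ccc(N(C)S(=O)(=O)C2CC3OC2C(c2ccc(NC(=O)CCCCCCC(=O)O)cc2)=C3c2ccc(O)cc2)cc1`: compound 2 gives > 100000 nM, again a limit rather than a number.
- compound 3, `CN(c1ccc(Cl)cc1)S(=O)(=O)C1CC2OC1C(c1ccc(NC(=O)CCCCCCC(=O)O)cc1)=C2c1ccc(O)cc1`: compound 3 gives 72100 nM.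

Among the measured compounds shown here, compound 3 therefore holds the only actual number in this assay; the other two values sit at the limit of > 100000 nM in this assay, at which 2 of the 3 values shown sit. The steps that can be read are an at least 1.3-fold lower number from compound 1 to compound 3 (0.14 log units; that floor lies within the scatter) and an at least 1.3-fold lower number from compound 2 to compound 3 (0.14 log units; that floor lies within the scatter), both floors that the scatter swallows, while a step that the two limits leave unreadable from compound 1 to compound 2 cannot be read at all.

Compound 4, `CN(c1cccc2ccccc12)S(=O)(=O)C1CC2OC1C(c1ccc(NC(=O)CCCCCCC(=O)O)cc1)=C2c1ccc(O)cc1`, differs from compound 3 by naphthalen-1-yl in place of 4-chlorophenyl on a sulfonamide nitrogen. For the measured compounds named here, none of the measured steps touches this place in this way: the measured pairs only exchange hydrogen, methyl and chloro on an aromatic carbon of the ring on the sulfonamide nitrogen, and none of them is resolved beyond the scatter. Nothing in the series therefore points to a direction for a whole second ring entering here, and the two limits leave only a weak frame. The working expectation is a step around compound 3 that stays within scatter, with a real chance that the assay again reports only a limit.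

Compound 4 is thus expected at 65000 nM, between 20000 nM and 200000 nM. The expected step is a 1.1-fold lower number from compound 3 to compound 4 (0.05 log units; within the scatter).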

Compound 4, half-maximal inhibitory concentration: 70900 nM
Compound 4: middle estimate off by 1.1-fold (0.04 log units), on the low side, within the range that was stated.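

In this assay, among the compounds shown here, the step of a 1.0-fold lower number from compound 3 to compound 4 (0.01 log units; within the scatter) is the first at this position with a real number at both ends, and it shows no resolved difference when naphthalen-1-yl, with 2 six-membered aromatic rings, replaces 4-chlorophenyl on the sulfonamide nitrogen. The comparisons with the two other compounds give only floors, an at least 1.4-fold lower number from compound 2 to compound 4 (0.14 log units; that floor lies within the scatter) for naphthalen-1-yl in place of 4-methylphenyl and an at least 1.4-fold lower number from compound 1 to compound 4 (0.14 log units; that floor lies within the scatter) for naphthalen-1-yl in place of phenyl, and neither floor clears the scatter. The step between compound 1 and compound 2 cannot be read, as the values at both of its ends are limits of the assay and not numbers: the limit of > 100000 nM in this assay, at which 2 of the 4 values shown sit.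

Still open, on these data alone, is whether any group on this sulfonamide nitrogen, such as a pyridine ring or a benzyl group, moves the number in this assay beyond the scatter. Also open, as far as these compounds go, is whether a change elsewhere on the shared core, such as a hydroxamic acid in place of the carboxylic acid, does so.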